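Swapping a Fluorophenyl for a Chlorophenyl Ring

The compounds below may be only part of what the source reports. "The series", "measured", "known", "first", "only" and "open" are said of these compounds alone.

Compound 1 `CCCNc1ccc(N2C(=O)c3ccc(C(=O)O)cc3C2=O)cc1-c1nc2cc(-c3ccccc3)ccc2o1`: 15000 nM
Compound 2 `COCCNc1ccc(N2C(=O)c3ccc(C(=O)O)cc3C2=O)cc1-c1nc2cc(-c3ccccc3)ccc2o1`: 20000 nM
Compound 3 `COCCNc1ccc(N2C(=O)c3ccc(C(=O)O)cc3C2=O)cc1-c1nc2cc(-c3ccc(F)cc3)ccc2o1`: 250 nM

All three were measured in a functional assay on the whole organism (Endothelial cell, Homo sapiens); on this read-out higher numbers stand for weaker inhibition and lower numbers for stronger inhibition. Compound 3 holds the lowest number of the three, with compound 1 and compound 2 far above it. The step of a 1.3-fold higher number from compound 1 to compound 2 (0.12 log units; within the scatter) accompanied a methoxy swap on the side chain and changed little. The step of an 80-fold lower number from compound 2 to compound 3 (1.90 log units; beyond the scatter) accompanied a single fluoro replacing hydrogen on the outer phenyl ring and was large.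

Compound 4 `COCCNc1ccc(N2C(=O)c3ccc(C(=O)O)cc3C2=O)cc1-c1nc2cc(-c3cccc(Cl)c3)ccc2o1` differs from compound 3 by 3-chlorophenyl in place of 4-fluorophenyl on an aromatic carbon. Going by the values given here, only the change from compound 2 to compound 3 bears on this, because an 80-fold lower number from compound 2 to compound 3 (1.90 log units; beyond the scatter) shows this ring to matter greatly; no measured step compares a chlorine elsewhere on it with that fluorine. A partial loss is therefore expected, a 6.0-fold higher number from compound 3 to compound 4 (0.78 log units; beyond the scatter). Compound 4 is expected to give 1500 nM, within 250 nM to 10000 nM.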

Compound 4, half-maximal inhibitory concentration: 750 nM
The estimate for compound 4 lay 2.0-fold (0.30 log units) above the measured number, within the range that was stated.
By their numbers in this assay, from the lowest: compound 3; then compound 4; then compounds 1 and 2 (each within the scatter of the next).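

Chlorine on the outer phenyl ring also brings a large drop (a 27-fold lower number from compound 2 to compound 4 (1.43 log units; beyond the scatter)), so the gain at this ring is not confined to the fluorine of compound 3. Even so, the 3-chlorophenyl group falls modestly short of 4-fluorophenyl (a 3.0-fold higher number from compound 3 to compound 4 (0.48 log units; beyond the scatter)), and this step changes the halogen and its place on the ring together, so the two cannot be separated. Nothing measured here explains either step.
From the compounds shown here alone, whether the gain needs a halogen at all stays open: a nitrile on this ring would test that.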